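Methoxy for fluoro on the anilino aryl of compound 3

The source may report more compounds than this note shows. Statements on the series, on what has been measured and on what is new or still open speak of the compounds shown alone.

Of the compounds shown here, three have numbers so far in a functional assay on K562 cells (Homo sapiens) for cytotoxicity, read by MTT assay, with a stated time of 72 h; on this read-out lower numbers stand for stronger inhibition and higher numbers for weaker inhibition. Compound 1 `COc1ccc(Nc2cccnc2)cc1` gives 68000 nM in this assay, compound 2 `COc1ccc(Nc2nc3ccccc3cc2-c2ccc(C)cc2)cc1` gives 75000 nM, and compound 3 `Cc1ccc(-c2ccnc(Nc3ccc(F)cc3)c2)cc1` gives 54000 nM. Compound 3 stands lowest of the three, yet its gaps to compound 1 and to compound 2 both lie within the scatter, so no order among them can be read from these numbers.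

Compound 4 `COc1ccc(Nc2cc(-c3ccc(C)cc3)ccn2)cc1` is not yet measured in this assay. Against compound 3 it shows (methoxy in place of fluoro on an aromatic carbon). Within the data shown here, the same methoxy sits on an aryl of compound 1, whose value of 68000 nM lies close to that of compound 3, and no other pair isolates this change.

The step from compound 3 to compound 4 is expected to stay within the scatter, with no clear direction, as a 1.1-fold higher number from compound 3 to compound 4 (0.05 log units; within the scatter). For compound 4 the estimate in this assay is 60000 nM, within a range from 25000 nM to 140000 nM.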

Compound 4, half-maximal inhibitory concentration: 19000 nM
Estimate against measurement, compound 4: 3.2-fold (0.50 log units) above; measured number below the stated range.
By their numbers in this assay, from the lowest: compound 4; then compounds 3, 1 and 2 (each within the scatter of the next).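

In this assay, among these compounds, the exchange of fluoro for methoxy on an aromatic carbon, para to a large group, gives a 2.8-fold lower number from compound 3 to compound 4 (0.45 log units; beyond the scatter) and is the first step that lies beyond the scatter. The earlier compounds shared no single-place difference, so this position is the first shown to respond to a change of group. The step is modest and rests on this one pair, so it sets no trend for methoxy elsewhere in the series.

Going by these compounds, whether the lower number follows from the oxygen, from the larger group or from both stays open, and a hydroxy group, an ethoxy group or an amine at the same place would help to separate these readings. No measurement shown here bears on the origin of this step.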